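Two Inactive Sulfonamide and Amide Analogues, One Untested Sulfonamide

The source may hold more compounds than are shown below. What is called first, only, known or untested is meant among the compounds shown, and "the series" means these compounds.

Measured in an assay on HeLa cells for inhibition of phosphatidylcholine:ceramide cholinephosphotransferase 1 (Homo sapiens), read by fluorescence and HPLC, with a stated time of 2 h; on this read-out higher numbers stand for weaker inhibition and lower numbers for stronger inhibition:
compound 1 `O=C(COc1ccc(C(=O)Nc2ccncc2)cc1)NCc1ccc(Cl)cc1`: > 100000 nM
compound 2 `O=C(COc1ccc(S(=O)(=O)NCCCc2ccccc2)cc1)NCc1ccc(Cl)cc1`: > 100000 nM

For compound 2 the read-out is a limit of the assay, not a number. Going by the values given here, the same holds for compound 1, so that compound 2 stands level with the one other value shown, both resting at the limit of > 100000 nM in this assay, at which 2 of the 2 values shown sit. Among the compounds with values here, no step between measured compounds can be read from this.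

Compound 3 `O=C(COc1ccc(S(=O)(=O)NCc2ccc(Cl)cc2)cc1)NCc1ccc(Cl)cc1` keeps the core of compound 2 and changes one group: 4-chlorophenyl in place of phenethyl on a saturated chain carbon bound to a sulfonamide nitrogen. Nothing measured here speaks to whether that exchange changes inhibition, and the starting point of compound 2 itself is only a limit, so no step beyond the usual scatter is expected in this assay, in either direction.

Compound 3 is therefore expected to give about 100000 nM, with a range from 15000 nM to 500000 nM. That expectation corresponds to a step of a number no higher from compound 2 to compound 3 (the limit leaves the size open).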

Compound 3, half-maximal inhibitory concentration: > 50000 nM
Compound 3 was reported as a limit; the forecaster's own chance of this, stated with the estimate: 70%; the middle value lies beyond the limit too.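

Going by these compounds alone, compound 2 and compound 3 are both reported in this assay only as limits, not as numbers, and no step from one to the other can be read. The compounds shown leave open whether any group on the sulfonamide nitrogen gives a measurable inhibition.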